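A Sulfonyl Swap Tested Against a Cytotoxicity Ceiling

The compounds below may be only part of what the source reports. "The series", "measured", "known", "first", "only" and "open" are said of these compounds alone.

Compound 3 `COc1ccc([C@H]2CC(=O)N(c3cccc(NCC4CCOC4)c3)C2)cc1OC1CCCC1` was examined in a functional assay on HEK293 cells (Homo sapiens) for cytotoxicity; on this read-out lower numbers stand for higher toxicity in this test and higher numbers for lower toxicity in this test. In this assay compound 3 gives > 10000 nM, which is a limit of the assay and not a number. Compound 1 `COc1ccc([C@H]2CC(=O)N(c3cc(N)cc(N)c3)C2)cc1OC1CCCC1` also returns a limit, giving > 10000 nM in this assay. Compound 2 `COc1ccc([C@H]2CC(=O)N(c3ccc(C#N)cc3)C2)cc1OC1CCCC1` likewise gives a limit of > 10000 nM in this assay. Among the compounds with values here, the only evidence is therefore (the limit of > 10000 nM in this assay, at which 3 of the 3 values shown sit), and the step that the two limits leave unreadable from compound 1 to compound 2 cannot be read. Compound 4 `COc1ccc([C@H]2CC(=O)N(c3cccc(NS(=O)(=O)c4ccccc4Cl)c3)C2)cc1OC1CCCC1` differs from compound 3 by the change ((2-chlorophenyl)sulfonyl in place of (oxolan-3-yl)methyl on a nitrogen on an aromatic ring). Within the data shown here, no measured step bears on this change, so the expected step that the limit leaves unreadable from compound 3 to compound 4 is none beyond the scatter, with compound 4 expected to remain at the ceiling. Compound 4 is estimated at 15000 nM, between 6000 nM and 40000 nM.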

Compound 4, half-maximal cytotoxic concentration: > 10000 nM
Compound 4: only a limit was reported; the forecaster's own chance of this, stated with the estimate: 75%; the middle value is on the limit's open side.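

In this assay compound 4 gives > 10000 nM, a limit of the assay and not a number, and the step from compound 3 to compound 4 cannot be read. The compounds shown leave open where the half-maximal cytotoxic concentration of any of them actually lies.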